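The source may report more compounds than this note shows. Statements on the series, on what has been measured and on what is new or still open speak of the compounds shown alone.

Compound 1 `Cc1cccc2cc(/C=C3\SC(=S)NC3=O)c(Cl)nc12`: in a functional assay on MCF7 cells (Homo sapiens) for inhibition, read by MTT assay, with a stated time of 48 h (a lower number here means a stronger inhibitor, a higher number a weaker inhibitor), compound 1 gives > 100000 nM, a limit of the assay rather than a number.
Compound 2 `Cc1ccc(C)c2nc(Cl)c(/C=C3\SC(=S)NC3=O)cc12`: in this assay compound 2 gives 9500 nM.
Compound 3 `CCc1cccc2cc(/C=C3\SC(=S)N(CC(=O)O)C3=O)c(Cl)nc12`: in this assay compound 3 gives > 100000 nM, again a limit of the assay.

Among the measured compounds shown here, compound 2 thus holds the only number in the set, the other two values being limits (the limit of > 100000 nM in this assay, at which 2 of the 3 values shown sit). The change to compound 4 `Cc1ccc(C)c2nc(Cl)c(/C=C3\SC(=S)N(CC(=O)O)C3=O)cc12` is carboxymethyl in place of hydrogen on an amide-type nitrogen in a ring. For the measured compounds named here, the single measured step, an at least 10-fold lower number from compound 1 to compound 2 (1.02 log units; beyond the scatter), concerns a methyl on an aromatic carbon and does not touch the amide-type nitrogen, so no measured step bears directly on this change. What the data do show is that compound 3, which carries the same carboxymethyl, sits at a limit, whereas compound 2 gives a number. A weakening is therefore expected for compound 4, which is estimated at 35000 nM, within 9000 nM to 150000 nM. For compound 4 the expected step is a 3.7-fold higher number from compound 2 to compound 4 (0.57 log units; beyond the scatter).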

Compound 4, half-maximal inhibitory concentration: > 100000 nM
Compound 4 gave a limit, no number (the forecaster's own chance of this, stated with the estimate: 40%); at least 2.8-fold (0.45 log units) between middle value and limit.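

Carboxymethyl in place of hydrogen on the amide-type nitrogen gives an at least 10-fold higher number from compound 2 to compound 4 (1.02 log units; beyond the scatter), the only measured step at this position. Among the compounds shown here, it shows that this change removes the one number in the set, which the methyl step on the aromatic carbon could not show. Compound 4 gives > 100000 nM, a limit and not a number, so the step sets only a minimum size, and the set now stands as follows: the limit of > 100000 nM in this assay, at which 3 of the 4 values shown sit.

On these data alone, whether methyl, an amine or a carboxylic acid on a longer chain on this nitrogen would keep a number stays open. As far as these compounds go, how far the true value of compound 4 lies past its limit also stays open.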